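This account rests on a few compounds, and the source may have more. Where it says the series, first, only, none or still open, it means among the compounds named here.

Three compounds of the series carry numbers in a functional assay on CHO-K1 cells for agonist activity at Glucose-dependent insulinotropic receptor (Homo sapiens), read by a luciferase reporter, with a stated time of 5 h; on this read-out higher numbers stand for an effect only at larger amounts of compound and lower numbers for an effect already at smaller amounts. Compound 1 `CC(C)(C)OC(=O)N1CCC(Oc2cccc3c2ccn3-c2ccc(S(C)(=O)=O)cc2)CC1` gives 631 nM. Compound 2 `CC(C)OC(=O)N1CCC(Oc2ncnc3c2CCN3c2ccc(S(C)(=O)=O)cc2)CC1` gives 126 nM. Compound 3 `CCCOC(=O)N1CCC(Oc2ncnc3c2CCN3c2ccc(S(C)(=O)=O)cc2F)CC1` gives 79.4 nM; this is the lowest of the three numbers, yet its gap to compound 2 lies within the scatter, while its gap to compound 1 lies beyond it. Compound 4 `CCSC(=O)N1CCC(Oc2ncnc3c2CCN3c2ccc(S(C)(=O)=O)cc2F)CC1` is not yet measured. It differs from compound 3 in one place: ethylsulfanyl in place of propoxy on a carbonyl carbon. Within the data shown here, no pair of measured compounds shows this change, so nothing fixes its size. The expected step of a 1.4-fold higher number from compound 3 to compound 4 (0.14 log units; within the scatter) is none beyond the scatter, leaning if anything toward a somewhat higher number. Compound 4 is therefore estimated at 110 nM, within 45 nM to 280 nM.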

Compound 4, half-maximal effective concentration: 31.6 nM
The estimate for compound 4 lay 3.5-fold (0.54 log units) above the measured number, outside the stated range (below it).
By their numbers in this assay, from the lowest: compound 4; then compounds 3 and 2 (each within the scatter of the next); then compound 1.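

In this assay, among these compounds, the exchange of propoxy for ethylsulfanyl on a carbonyl carbon gives a 2.5-fold lower number from compound 3 to compound 4 (0.40 log units; beyond the scatter) and is the only single-place step. The group on this carbonyl carbon can therefore shift the number beyond the scatter, and the ethylsulfanyl compound holds the lowest number of the four. Nothing at hand explains the step.

Open, as far as these compounds go, is whether the sulfur link or the chain length carries the step: ethoxy and propylsulfanyl on the same carbonyl carbon would separate the two. Also open, from the compounds shown here alone, is how an amine at this place would read.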